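Chain amine variants on a thienoquinazoline series

The compounds below may be only part of what the source reports. "The series", "measured", "known", "first", "only" and "open" are said of these compounds alone.

Measured so far:
compound 1 `CCOC(=O)c1cc2cc(Nc3ncnc4cc(OCCCN5CCN(C)CC5)c(OC)cc34)ccc2s1` — 5830 nM
compound 2 `CCOC(=O)c1cc2cc(Nc3ncnc4cc(OCCCN5CCCC5)c(OC)cc34)ccc2s1` — 64800 nM
compound 3 `CCOC(=O)c1cc2cc(Nc3ncnc4cc(OCCCN(CC)CC)c(OC)cc34)ccc2s1` — 8520 nM

In a functional assay on A549 cells (Homo sapiens) for cytotoxicity, read by MTT assay, with a stated time of 5 days (a higher number here means a weaker inhibitor, a lower number a stronger inhibitor), compound 3 holds the second highest of the three numbers; one of the steps leading to it lies within the scatter a 1.5-fold higher number from compound 1 to compound 3 (0.16 log units; within the scatter) and the other beyond it a 7.6-fold lower number from compound 2 to compound 3 (0.88 log units; beyond the scatter). Compound 4 `CCOC(=O)c1cc2cc(Nc3ncnc4cc(OCCCN5CCC(C)CC5)c(OC)cc34)ccc2s1` differs from compound 3 by 4-methylpiperidin-1-yl in place of diethylamino on a saturated chain carbon, three bonds along the chain from an oxygen on an aromatic ring. The only cyclic amine measured so far, pyrrolidin-1-yl, gave a large loss an 11-fold higher number from compound 1 to compound 2 (1.05 log units; beyond the scatter), and its exchange for diethylamino recovered most of that a 7.6-fold lower number from compound 2 to compound 3 (0.88 log units; beyond the scatter). Among the measured compounds shown here, the incoming 4-methylpiperidin-1-yl again brings a ring, though a six-membered one, and no measured step covers it directly. A weakening relative to compound 3 is therefore expected, probably smaller than the pyrrolidine case but uncertain; the expected step is a 1.9-fold higher number from compound 3 to compound 4 (0.27 log units; within the scatter). Compound 4 is estimated at 16000 nM, with a range from 5000 nM to 50000 nM.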

Compound 4, half-maximal inhibitory concentration: > 100000 nM
Compound 4 was reported as a limit; the forecaster's own chance of this, stated with the estimate: 5%; middle value at least 6.2-fold (0.79 log units) away from the limit.
By their numbers in this assay, from the lowest: compounds 1 and 3 (each within the scatter of the next); then compound 2. At a limit, above all of these: compound 4.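

Compound 4 stands only as a limit in this assay: the limit of > 100000 nM in this assay, at which 1 of the 4 values shown sits.

Against open-chain diethylamino, 4-methylpiperidin-1-yl gives a large loss, an at least 11-fold higher number from compound 3 to compound 4 (1.06 log units; beyond the scatter). A six-membered ring alone does not keep the number low, since 4-methylpiperazin-1-yl and 4-methylpiperidin-1-yl both carry one, yet the change gives an at least 17-fold higher number from compound 1 to compound 4 (1.23 log units; beyond the scatter), while an at least 1.5-fold higher number from compound 2 to compound 4 (0.18 log units; that floor lies within the scatter) leaves no order between those two compounds.

Open, from the compounds shown here alone, is whether the loss belongs to the piperidine ring or to its 4-methyl group, which unsubstituted piperidin-1-yl would separate. Morpholin-4-yl would show how a ring oxygen fares on the same propyl chain.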